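Swapping methyl for chloro on the aromatic ring

The source may hold more compounds than are shown below. What is called first, only, known or untested is meant among the compounds shown, and "the series" means these compounds.

For the measured compounds named here, in a functional assay on the whole organism for antagonist activity, with Mus musculus as the target (a lower number here means that less compound is needed, a higher number that more compound is needed for the effect), compound 1 `CCC(=O)N(c1ccccc1C)C1CCCC1N(C)C` gives 5 mg/kg as the only true number so far. Compound 2 `CCC(=O)N(c1c(F)c(F)c(F)c(F)c1F)C1CCCC1N(C)C` reads > 50 mg/kg, which is a limit of this assay and not a number. Compound 3 `CCC(=O)N(c1ccccc1Cl)C1CCCC1N(C)C` carries chloro in place of methyl on an aromatic carbon, ortho to a large group (chloro in place of methyl on an aromatic carbon). Going by the values given here, no measured pair shows this swap. The estimated step (a 1.2-fold higher number from compound 1 to compound 3 (0.08 log units; within the scatter)) is expected to stay within the usual scatter, with no firm direction. Compound 3 is expected to give 6 mg/kg with 2 mg/kg to 20 mg/kg as its estimated range.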

Compound 3, dose for half-maximal effect: 2 mg/kg
Estimate against measurement, compound 3: 3.0-fold (0.48 log units) above; the range from low to high includes it.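

In this assay, this place on the aromatic ring proves sensitive to a single-atom swap: chloro in place of methyl gives a 2.5-fold lower number from compound 1 to compound 3 (0.40 log units; beyond the scatter), so less compound is needed for the effect. For the compounds shown here, the earlier compounds held no pair differing only here, so this is the first direct reading of a change at this place. Nothing shown explains the step.

Still open, on these data alone, is how other groups, such as methoxy or a nitrile, would read at this same place. Also open, as far as these compounds go, is whether bromo would continue the step seen with chloro.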